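Replacing the pendant aryl with acetyl on the shared core

The source may hold more compounds than are shown below. What is called first, only, known or untested is meant among the compounds shown, and "the series" means these compounds.

Within the data shown here, compound 2 `NS(=O)(=O)c1ccc(-c2cnc(C(=O)CCCCCCc3ccccc3)o2)s1` gives 3 nM in an assay (Rattus norvegicus) for inhibition of Fatty-acid amide hydrolase 1 (Homo sapiens) (on this read-out higher numbers stand for weaker inhibition and lower numbers for stronger inhibition), the higher of the two numbers recorded, with compound 1 `Cc1ccc(-c2cnc(C(=O)CCCCCCc3ccccc3)o2)nc1` at 2.8 nM as its only neighbour; the step of a 1.1-fold higher number from compound 1 to compound 2 (0.03 log units; within the scatter) stays within the scatter. Compound 3 `CC(=O)c1cnc(C(=O)CCCCCCc2ccccc2)o1` is the next change: acetyl in place of 5-sulfamoylthiophen-2-yl on an aromatic carbon. Among the measured compounds shown here, the single measured step swapped one ring-bearing group for another and says nothing about removing the ring altogether, so it bears only loosely here. A weaker number seems the likelier outcome, with wide uncertainty. Compound 3 is estimated at 30 nM, range 8 nM to 120 nM, which would mean a 10-fold higher number from compound 2 to compound 3 (1.00 log units; beyond the scatter).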

Compound 3, inhibition constant: 2 nM
Estimate against measurement, compound 3: 15-fold (1.18 log units) above; measured number outside the range, below it.
By their numbers in this assay, from the lowest: compounds 3, 1 and 2 (each within the scatter of the next).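

In this assay, acetyl on this aromatic carbon next to the ring oxygen matches both ring-bearing groups (a 1.5-fold lower number from compound 2 to compound 3 (0.18 log units; within the scatter); a 1.4-fold lower number from compound 1 to compound 3 (0.15 log units; within the scatter)), and both steps lie within the scatter. An aromatic ring on this carbon is therefore not needed to hold the number among these compounds, and 3 heavy atoms serve as well as 9. Nothing available accounts for this result.
Still open, going by these compounds, is whether a carboxylic acid, an amine or a methyl ester on this carbon would keep the number. A bare hydrogen here would show whether any group is needed at all.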